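Mirror image of compound 3: expected lipophilicity

The compounds below may be only part of what the source reports. "The series", "measured", "known", "first", "only" and "open" are said of these compounds alone.

Compound 1 `Cc1cc(C)c(CN2CCc3c(Cl)cc([C@@H](CO)[C@@H]4CCOC4)c(Cl)c3C2=O)c(=O)[nH]1`, compound 2 `Cc1cc(C)c(CN2CCc3c(Cl)cc([C@@H](CO)[C@@H]4CCCO4)c(Cl)c3C2=O)c(=O)[nH]1` and compound 3 `Cc1cc(C)c(CN2CCc3c(Cl)cc([C@@H](CO)[C@H]4CCCO4)c(Cl)c3C2=O)c(=O)[nH]1` share one core and differ only in the oxolane and its configuration. In a physicochemical assay for lipophilicity, at pH 7.4 (a lower number here means a more polar compound, a higher number a more lipophilic compound), compound 1 gives 2, compound 2 gives 2.1 and compound 3 gives 2.5. Compound 3 stands highest of the three numbers, with compound 2 nearest and compound 1 furthest from it. The measured steps are a number 0.10 log units higher from compound 1 to compound 2 (within the scatter), a number 0.50 log units higher from compound 1 to compound 3 (beyond the scatter) and a number 0.40 log units higher from compound 2 to compound 3 (beyond the scatter); the last of these rests on (the fact that compounds 2 and 3 differ only in the configuration as drawn), with 1 of 2 stereo elements changed.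

Among the measured compounds shown here, compound 4 `Cc1cc(C)c(CN2CCc3c(Cl)cc([C@H](CO)[C@@H]4CCCO4)c(Cl)c3C2=O)c(=O)[nH]1` has not yet been measured in this assay. the two compounds have the same atoms and bonds and differ only in configuration as drawn: 2 of 2 stereo elements differ (all stereocentres are inverted: mirror images); a stereocentre at a saturated chain carbon is drawn S in compound 3 and R in compound 4; a stereocentre at a saturated ring carbon is drawn R in compound 3 and S in compound 4 The step from compound 2 to compound 3 is the only measured one that changes configuration alone, but it inverts a single stereocentre, whereas compound 4 inverts both, so that compounds 3 and 4 are mirror images. Mirror images are expected to give the same number in this assay. For compound 4 no step beyond the scatter is expected, no change at the digits printed from compound 3 to compound 4 (within the scatter). Compound 4 is therefore estimated at 2.5, with a range from 2.2 to 2.8.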

Compound 4, distribution coefficient: 2.4
Compound 4: middle estimate off by 0.10 log units, on the high side, and the stated range covers the measured number.
By their numbers in this assay, from the lowest: compounds 1, 2, 4 and 3 (each within the scatter of the next, the first and the last beyond it).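

In this assay the mirror-image pair stays within the scatter (a number 0.10 log units lower from compound 3 to compound 4 (within the scatter)), and this pair carries no more than the following: the fact that compounds 3 and 4 differ only in the configuration as drawn

Compound 2 relates to compound 3 and to compound 4 by a single inverted stereocentre, yet one step lies beyond the scatter (a number 0.40 log units higher from compound 2 to compound 3 (beyond the scatter)) and the other within it (a number 0.30 log units higher from compound 2 to compound 4 (within the scatter)), so the effect of configuration here sits at the edge of what this assay resolves: the fact that compounds 2 and 4 differ only in the configuration as drawn

Against the oxolan-3-yl compound 1, compound 4 also lies beyond the scatter (a number 0.40 log units higher from compound 1 to compound 4 (beyond the scatter)), as compound 3 does, while compound 2 does not, so moving the ring oxygen gives no single step independent of configuration.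

From the compounds shown here alone, the mirror image of compound 2 and that of compound 1 remain open, so the pattern rests on one enantiomeric pair. Going by these compounds, how the number moves with a pyrrolidine or a morpholine in place of the oxolane also remains open.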